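Bromine for Chlorine on the Amine of Compound 3

The compounds below may be only part of what the source reports. "The series", "measured", "known", "first", "only" and "open" are said of these compounds alone.

Compound 3 `Fc1cccc(-c2nc(Nc3ccc(Cl)cc3)c3cc(F)ccc3n2)c1` belongs to a small set of three examined in a functional assay on MDA-MB-231 cells (Homo sapiens) for cytotoxicity, read by MTT assay, with a stated time of 48 h; on this read-out higher numbers stand for weaker inhibition and lower numbers for stronger inhibition. In this assay compound 3 gives only a limit, > 50000 nM, so its place among the numbers shown is no more than the edge of the measurable range. Its companions stand the same way. Compound 1 `Fc1ccc2nc(-c3ccccc3)nc(Nc3ccccc3)c2c1` gives the limit > 50000 nM in this assay. Compound 2 `Fc1cccc(-c2nc(Nc3ccccc3F)c3cc(F)ccc3n2)c1` likewise gives the limit > 50000 nM in this assay. For the measured compounds named here, the single step between neighbours, a step that the two limits leave unreadable from compound 2 to compound 3, cannot be read in size or direction because both of its ends sit at the limit of > 50000 nM in this assay, at which 3 of the 3 values shown sit.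

Compound 4 `Fc1cccc(-c2nc(Nc3ccccc3Br)c3cc(F)ccc3n2)c1` differs from compound 3 by 2-bromophenyl in place of 4-chlorophenyl on a nitrogen on an aromatic ring. Going by the values given here, the one measured step that bears on this kind of exchange, a step that the two limits leave unreadable from compound 2 to compound 3, also trades one halogenated phenyl for another, and it tells nothing of size. With no readable step in the set, the expectation for compound 4 can only follow the three limits already seen: no change beyond the scatter, a step that the limit leaves unreadable from compound 3 to compound 4. Compound 4 is therefore estimated to give 60000 nM in this assay, within a range from 20000 nM to 200000 nM, most likely reported again as a limit.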

Compound 4, half-maximal inhibitory concentration: > 50000 nM
Compound 4 was reported as a limit; the forecaster's own chance of this, stated with the estimate: 85%; the middle value does not contradict the limit.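

Compound 4, like compound 2 and compound 3, stands only as a limit in this assay, so neither step to compound 4, from compound 2 or from compound 3, can be read in size or direction: the limit of > 50000 nM in this assay, at which 4 of the 4 values shown sit. The compounds shown leave open whether any change on the shared core would bring a value inside the measurable range.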